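This account rests on a few compounds, and the source may have more. Where it says the series, first, only, none or still open, it means among the compounds named here.

Measured so far in a functional assay on OVCAR-3 cells (Homo sapiens) for inhibition, read by MTT assay, with a stated time of 24 h; on this read-out lower numbers stand for stronger inhibition and higher numbers for weaker inhibition:
- compound 1 `CC1(C)[C@H]2CC[C@]1(C)N(Cc1cn(-c3ccc(C#N)cc3)nn1)C(=O)C2` gives 380 nM
- compound 2 `CC1(C)[C@H]2CC[C@]1(C)N(Cc1cn(-c3cccc(C#N)c3)nn1)C(=O)C2` gives 230 nM
- compound 3 `CC1(C)[C@H]2CC[C@]1(C)N(Cc1cn(-c3ccc(O)cc3)nn1)C(=O)C2` gives 410 nM

Compound 2 cannot be ranked against the other two. Both of its steps (a 1.7-fold lower number from compound 1 to compound 2 (0.22 log units; within the scatter)) and (a 1.8-fold higher number from compound 2 to compound 3 (0.25 log units; within the scatter)) lie within the scatter, so these three compounds read as one level of inhibition.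

Compound 4 `CC1(C)[C@H]2CC[C@]1(C)N(Cc1cn(-c3ccccc3)nn1)C(=O)C2` is compound 2 with one edit: hydrogen in place of cyano on an aromatic carbon, which turns 3-cyanophenyl into phenyl (hydrogen in place of cyano on an aromatic carbon). Among the compounds with values here, no measured compound carries a bare phenyl, so no measured step shows this change directly. The closest evidence is two steps that swap a cyano group for hydroxy (a 1.1-fold higher number from compound 1 to compound 3 (0.03 log units; within the scatter)) and (a 1.8-fold higher number from compound 2 to compound 3 (0.25 log units; within the scatter)). Moving the cyano group, seen in the first step above, is the only other comparison. All of these stayed within the scatter, so no step beyond the scatter is expected in this assay here, although a slight drift toward the values of the other two compounds is possible. The estimated change is small (a 1.4-fold higher number from compound 2 to compound 4 (0.16 log units; within the scatter)) and remains an expectation. The estimate for compound 4 is 330 nM with an expected range from 150 nM to 750 nM in this read-out.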

Compound 4, half-maximal inhibitory concentration: 50 nM
For compound 4 the middle estimate is 6.6-fold (0.82 log units) above the measured one; the measured number lies below the stated range.
By their numbers in this assay, from the lowest: compound 4; then compounds 2, 1 and 3 (each within the scatter of the next).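

In this assay, the bare phenyl of compound 4 stands apart from all three substituted rings, with a 4.6-fold lower number from compound 2 to compound 4 (0.66 log units; beyond the scatter) and a 7.6-fold lower number from compound 1 to compound 4 (0.88 log units; beyond the scatter) as well as an 8.2-fold lower number from compound 3 to compound 4 (0.91 log units; beyond the scatter), and each of these steps lies beyond the scatter. The earlier compounds shown here could not show this: they only exchanged one ring substituent for another, and 3-cyanophenyl, 4-cyanophenyl and 4-hydroxyphenyl all read as one level, so what matters here is whether the ring carries a substituent at all, not which of these three it is. Nothing available on these compounds accounts for this difference.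

The ring carries only a nitrile or a hydroxy group in the compounds shown, so it stays open whether a fluorine, a methyl, a methoxy or an amine on the same ring would join that higher level or stay close to compound 4. All four compounds also share one core, which leaves open whether a bare phenyl would give the same advantage on a different core.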